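This account rests on a few compounds, and the source may have more. Where it says the series, first, only, none or still open, it means among the compounds named here.

Measured so far in a functional assay on the whole organism (Tail, strain ICR) with Mus musculus as the target, in the tail flick test, with a stated time of 60 min, at a dose of 25 umol/kg by the oral route; on this read-out higher numbers stand for a stronger effect at the one dose given and lower numbers for a weaker effect:
compound 1 `CC[C@H](C)[C@H](NC(=O)CN(c1nc(Cl)nc2[nH]cnc12)C1CC1)C(=O)O`: 36%
compound 2 `C[C@@H](O)[C@H](NC(=O)CN(c1nc(Cl)nc2[nH]cnc12)C1CC1)C(=O)OCc1ccccc1`: 29.7%
compound 3 `CC[C@H](C)[C@H](NC(=O)CN(c1nc(Cl)nc2[nH]cnc12)C1CC1)C(=O)OCc1ccccc1`: 40.6%

Compound 1 stands second of the three numbers in this assay. Its nearest neighbour is compound 3, at a number 4.6 percentage points higher from compound 1 to compound 3 (within the scatter), a gap within the scatter; compound 2 lies furthest from it, and the gap between those two values is also within the scatter, so no order among compounds 1, 2 and 3 can be stated from these values alone. Among the compounds with values here, the one step beyond the scatter is a number 10.9 percentage points higher from compound 2 to compound 3 (beyond the scatter), a modest change on the side chain.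

Compound 4 `CC(C)[C@H](NC(=O)CN(c1nc(Cl)nc2[nH]cnc12)C1CC1)C(=O)O` differs from compound 1 by hydrogen in place of methyl on a saturated chain carbon, three bonds along the chain from an amide-type nitrogen and a carbonyl carbon. Within the data shown here, no measured step touches this particular change. The step from compound 2 to compound 3 is the only one that alters the same side chain, and it is modest; the step from compound 1 to compound 3 changes a different position and stays within the scatter. Among the measured compounds shown here, removing one methyl from the side chain is a smaller alteration than the one seen between compound 2 and compound 3, so the expectation for this assay is no step beyond the scatter, with a slight lean downward given that compound 1 sits already below compound 3.

Compound 4 is therefore estimated at 32% (range 20% to 45%), which means an expected step of a number 4 percentage points lower from compound 1 to compound 4 (within the scatter).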

Compound 4, a percentage reported as activity, at one dose (the size of the read-out at that dose, not a potency): 38.8%
For compound 4 the middle estimate is 6.8 percentage points below the measured one, within the range that was stated.
By their numbers in this assay, from the lowest: compounds 2, 1, 4 and 3 (each within the scatter of the next, the first and the last beyond it).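

In this assay the change from sec-butyl to isopropyl on the free acid gives a number 2.8 percentage points higher from compound 1 to compound 4 (within the scatter) and thus shows that the methyl on this saturated chain carbon, three bonds along the chain from an amide-type nitrogen and a carbonyl carbon, can be replaced by hydrogen with no readable change at this one dose. Within the data shown here, the only earlier step on this side chain, a number 10.9 percentage points higher from compound 2 to compound 3 (beyond the scatter) and seen on the benzyl esters, put ethyl in place of hydroxy, so the series now holds one side-chain change beyond the scatter and one within it, each on a different ester or acid background. No measurement at hand bears on why the read-out holds at this place.

Open, from the compounds shown here alone, is whether hydrogen in place of methyl reads the same on the benzyl ester as on the free acid. Also open, going by these compounds, is how a longer chain, a phenyl ring or an amine at this place would compare with sec-butyl and isopropyl, and whether any such group would move the read-out beyond the scatter.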